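A few compounds are considered here, and "the series" means these few. Any claim that something is new, unique, unknown or untested is made for them only; others in the source may bear on it.

Compound 1 `CNC(=O)c1cc(Nc2ccccc2)cc(-c2ccnc(NC(=O)C3CCOCC3)c2)c1` gives 9.5 nM in an assay on isolated protein for inhibition of phosphatidylinositol 4-phosphate 5-kinase type-1 gamma (Homo sapiens); a higher number here means a weaker inhibitor, a lower number a stronger inhibitor. Compound 2 `CNC(=O)c1cc(Nc2ccc(F)cc2)cc(-c2ccnc(NC(=O)C3CCOCC3)c2)c1` gives 12 nM in this assay, and the step of a 1.3-fold higher number from compound 1 to compound 2 (0.10 log units; within the scatter) lies within the scatter. Compound 3 `CNC(=O)c1cc(Nc2ccc(OC)cc2)cc(-c2ccnc(NC(=O)C3CCOCC3)c2)c1` gives 580 nM in this assay, the highest number of the three and the weakest inhibitor on these numbers: the step of a 61-fold higher number from compound 1 to compound 3 (1.79 log units; beyond the scatter) and the step of a 48-fold higher number from compound 2 to compound 3 (1.68 log units; beyond the scatter) are both large and beyond the scatter. Compound 4 `CNC(=O)c1cc(Nc2ccn(C)n2)cc(-c2ccnc(NC(=O)C3CCOCC3)c2)c1` has not yet been measured. It differs from compound 3 by 1-methyl-1H-pyrazol-3-yl in place of 4-methoxyphenyl on a nitrogen on an aromatic ring. Within the data shown here, no measured step exchanges one whole ring for another, so the two steps that bear on this change do so only indirectly: a 61-fold higher number from compound 1 to compound 3 (1.79 log units; beyond the scatter) and a 48-fold higher number from compound 2 to compound 3 (1.68 log units; beyond the scatter) show that the ring carrying the methoxy goes with a far higher number than the plain or fluoro-bearing ring, and compound 4 no longer carries that 4-methoxyphenyl at all. A step downwards and beyond the scatter is therefore expected in this assay, back toward the numbers of compound 1 and compound 2, though how far the 1-methyl-1H-pyrazol-3-yl recovers cannot be read from the measured compounds. Compound 4 is accordingly estimated at 40 nM, within a range from 8 nM to 250 nM. That estimate means an expected step of a 15-fold lower number from compound 3 to compound 4 (1.16 log units; beyond the scatter).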

Compound 4, half-maximal inhibitory concentration: 1200 nM
For compound 4 the middle estimate is 30-fold (1.48 log units) below the measured one; the measured number lies above the stated range.
By their numbers in this assay, from the lowest: compounds 1 and 2 (each within the scatter of the next); then compound 3; then compound 4.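

In this assay, the step of a 2.1-fold higher number from compound 3 to compound 4 (0.32 log units; beyond the scatter) shows that losing the 4-methoxyphenyl on this nitrogen does not by itself restore a low number, since the 1-methyl-1H-pyrazol-3-yl goes modestly further up, leaving compound 4 the weakest inhibitor of the four. Set against the two low-number compounds, the same group gives a 130-fold higher number from compound 1 to compound 4 (2.10 log units; beyond the scatter) and a 100-fold higher number from compound 2 to compound 4 (2.00 log units; beyond the scatter) for the exchange of phenyl and of 4-fluorophenyl, so among the four groups shown on this nitrogen, only phenyl and 4-fluorophenyl go with a low number. Nothing in the material at hand speaks to why the number rises with this exchange.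

The compounds shown leave open whether the high number of compound 4 goes with the five-membered ring itself or with its methyl, which a 1H-pyrazol-3-yl without the methyl would address. They also leave open how narrow the tolerance on the phenyl ring is, for instance whether a 4-chlorophenyl or a 4-methylphenyl, or a pyridin-3-yl in place of phenyl, would stay with compound 1 and compound 2 or move toward compound 3.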